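The compounds below may be only part of what the source reports. "The series", "measured", "known", "first", "only" and "open" are said of these compounds alone.

Compound 1 `CCN(C(C)=O)C1CCN(c2nc(-c3ccccn3)nc3c2CN(Cc2ccc(Cl)cc2)CC3)C1`: 100000 nM
Compound 2 `NC(=O)CN1CCN(c2nc(-c3cccnc3)nc3c2CN(Cc2ccccc2)CC3)CC1`: 100000 nM
Compound 3 `C=CCc1cc(-c2sc(NC(=O)C(C)(C)C)nc2C)nn1C(=O)Nc1ccccc1`: 3020 nM

In an assay on cells with Cystic fibrosis transmembrane conductance regulator variant F508del (Homo sapiens) as the target, read by fluorescence, with stated times of 24 h and 30 min (a lower number here means that less compound is needed, a higher number that more compound is needed for the effect), compound 2 gives 100000 nM, level with compound 1 at the digits shown, and together these two stand at the highest number of the three; compound 3, whose structure differs throughout, gives 3020 nM, the lowest number of the set. Compound 4 `CN1CCN(CCCNc2nc(-c3cccnc3)nc3c2CN(Cc2ccccc2)CC3)CC1` is not yet measured. It keeps the core of compound 2 and differs in one place: (3-(4-methylpiperazin-1-yl)propyl)amino in place of 4-(carbamoylmethyl)piperazin-1-yl on an aromatic carbon. Within the data shown here, no measured pair shows a step of this kind, so nothing in the data points to a change beyond the usual scatter; the expected step of a 1.3-fold lower number from compound 2 to compound 4 (0.10 log units; within the scatter) is therefore close to none. The estimate for compound 4 in this assay is 80000 nM, within 20000 nM to 100000 nM.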

Compound 4, half-maximal effective concentration: 100000 nM
Estimate against measurement, compound 4: 1.3-fold (0.10 log units) below; the range from low to high includes it.
By their numbers in this assay, from the lowest: compound 3; then compounds 1, 2 and 4 (each within the scatter of the next).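

In this assay, (3-(4-methylpiperazin-1-yl)propyl)amino in place of 4-(carbamoylmethyl)piperazin-1-yl on this aromatic carbon gives no change at the digits printed from compound 2 to compound 4 (within the scatter), the first step read at this position. The carbamoylmethyl group and the ring attached directly to the aromatic carbon can thus both be exchanged here with no change in the number. No available evidence accounts for this result.

From the compounds shown here alone, whether a morpholine or a carboxylic acid at this position would shift the number remains open. Going by these compounds, whether a shorter amine chain would do so remains open too.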